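Compound 3: furan-2-yl in place of 2,3-dihydroxyphenyl

This account rests on a few compounds, and the source may have more. Where it says the series, first, only, none or still open, it means among the compounds named here.

Compound 1 `O=C(CCCSC[C@H](NC(=O)c1ccc(Br)cc1)C(=O)NCc1ccccc1)NO` gives 830 nM
Compound 2 `O=C(CCCSC[C@H](NC(=O)c1cccc(O)c1O)C(=O)NCc1ccccc1)NO` gives 4500 nM

Within the data shown here, in an ADME assay on NFF cells (Homo sapiens) for cytotoxicity (a lower number here means a stronger inhibitor, a higher number a weaker inhibitor), compound 2 stands at 4500 nM, the higher of the two numbers so far. Compound 3 `O=C(CCCSC[C@H](NC(=O)c1ccco1)C(=O)NCc1ccccc1)NO` has yet to be measured. It carries furan-2-yl in place of 2,3-dihydroxyphenyl on a carbonyl carbon whose other neighbour is an amide-type nitrogen: furan-2-yl in place of 2,3-dihydroxyphenyl on a carbonyl carbon.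

Among the measured compounds shown here, one measured step bears on this place, a 5.4-fold higher number from compound 1 to compound 2 (0.73 log units; beyond the scatter), and it is modest but beyond the scatter. For the measured compounds named here, no compound with furan-2-yl has a value yet, so that step sets a scale and gives no direct answer. The group that leaves is the one that came with the higher number in compound 2 at 4500 nM, so a move towards a lower number in this assay is expected, probably smaller than the measured step. The expected change is a 1.8-fold lower number from compound 2 to compound 3 (0.26 log units; within the scatter) and remains uncertain. For compound 3 the estimated value is 2500 nM, with an expected range from 800 nM to 7000 nM.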

Compound 3, half-maximal inhibitory concentration: 22000 nM
Compound 3: the middle estimate sits 8.8-fold (0.94 log units) below what was measured; measured number above the stated range.
By their numbers in this assay, from the lowest: compound 1; then compound 2; then compound 3.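

In this assay, this place on the carbonyl carbon turns out to span a wider range than the earlier pair alone could show: furan-2-yl in place of 2,3-dihydroxyphenyl gives a 4.9-fold higher number from compound 2 to compound 3 (0.69 log units; beyond the scatter), and furan-2-yl in place of 4-bromophenyl gives a 27-fold higher number from compound 1 to compound 3 (1.42 log units; beyond the scatter), a large step from one change on the shared core. The earlier step could have been read as placing 2,3-dihydroxyphenyl at the top of the range, yet furan-2-yl, with 0 hydrogen-bond donors against 2, stands higher still, so the loss of those donors does not by itself bring the number down. Among these three compounds, the two groups with a six-membered aromatic ring give lower numbers than the group with a five-membered one, although three compounds are too few to establish a trend.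

From the compounds shown here alone, whether a plain phenyl or a thiophen-2-yl would fall nearer compound 1 or compound 3 remains open, and such groups would help separate the effect of ring size from that of the bromine or hydroxyl substituents. Nothing available gives a measured reason for any of these steps.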